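Adding butyl to the chain of compound 1

This account rests on a few compounds, and the source may have more. Where it says the series, first, only, none or still open, it means among the compounds named here.

Compound 1 (`CCCCCCc1c(O)cc(C)oc1=O`): > 200000 nM, a limit
Compound 2 (`Cc1cc(O)c(C(=O)CCC2CCCCC2)c(=O)o1`): 117000 nM

In an ADME assay on L929 cells (Mus musculus, culture collection number NCTC 929) for cytotoxicity, read by MTT assay, with a stated time of 72 h (on this read-out lower numbers stand for stronger inhibition and higher numbers for weaker inhibition), compound 1 stands at the limit of > 200000 nM in this assay, at which 1 of the 2 values shown sits. Compound 2 gives an actual number, 117000 nM. Compound 3 (`CCCCCCCCCCc1c(O)cc(C)oc1=O`) differs from compound 1 by one change, butyl in place of hydrogen on a saturated chain carbon (butyl in place of hydrogen on a saturated chain carbon, six bonds along the chain from an aromatic carbon). Among the measured compounds shown here, no measured pair shows what such a change does, so any forecast is uncertain. A moderate move towards stronger inhibition is expected, an at least 2.5-fold lower number from compound 1 to compound 3 (0.39 log units; beyond the scatter). For compound 3 the estimated value is 80000 nM, with an expected range of 20000 nM to 200000 nM.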

Compound 3, half-maximal inhibitory concentration: 56000 nM
Beside the measured number, compound 3's estimate is 1.4-fold (0.15 log units) above it; measured number inside the range.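

In this assay, among the compounds shown here, butyl in place of hydrogen on this saturated chain carbon gives the first readable step at this position: an at least 3.5-fold lower number from compound 1 to compound 3 (0.55 log units; beyond the scatter). So this longer chain goes with stronger inhibition, and compound 3 gives a real number. From the compounds shown here alone, the step's full size stays unknown because compound 1 gives only a limit: the limit of > 200000 nM in this assay, at which 1 of the 3 values shown sits. Going by these compounds, whether a still longer chain would lower the number further remains open, as does whether an amine or a carboxylic acid at the chain end would give a similar step.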